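This account rests on a few compounds, and the source may have more. Where it says the series, first, only, none or still open, it means among the compounds named here.

In an ADME assay on Huh-7 cells (Homo sapiens) for cytotoxicity, with a stated time of 3 days (a lower number here means that less compound is tolerated, a higher number that more compound is tolerated), compound 1 `COc1cccc(NC(=O)c2c(NO)cc(-c3ccccc3)oc2=O)c1` gives only a limit, > 20000 nM. Compound 2 `Cc1ccccc1NC(=O)c1c(NO)cc(-c2cccs2)oc1=O` likewise returns only a limit, > 20000 nM. Compound 3 `O=C(Nc1ccccc1)c1c(NCCO)cc(-c2cccc(Br)c2)oc1=O` again reaches only a limit, > 20000 nM. Compound 3 therefore stands where every measured member of the series stands: at the limit of > 20000 nM in this assay, at which 3 of the 3 values shown sit, so none of the three has yet yielded a number in this assay and no ordering among them can be drawn.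

Compound 4 `O=C(Nc1ccc(Br)cc1)c1c(NCCO)cc(-c2cccc(Br)c2)oc1=O` is not yet measured in this assay. It differs from compound 3 by bromo in place of hydrogen on an aromatic carbon, para to a large group; cut one bond further out, anilino becomes (4-bromophenyl)amino. Within the data shown here, no step between measured compounds exists to calibrate this change, and with all measured values resting at the limit of > 20000 nM in this assay, at which 3 of the 3 values shown sit, there is nothing that points to a direction. The step expected in this assay is a step that the limit leaves unreadable from compound 3 to compound 4, none beyond the scatter. Compound 4 is expected to give 25000 nM, with a range from 8000 nM to 60000 nM, most probably reported once more only as a limit.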

Compound 4, half-maximal cytotoxic concentration: > 20000 nM
Compound 4 was reported as a limit; the forecaster's own chance of this, stated with the estimate: 80%; the middle value does not contradict the limit.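

Compound 4, like compound 3, is reported only as a limit, so no step can be read between compound 3 and compound 4: the limit of > 20000 nM in this assay, at which 4 of the 4 values shown sit. The compounds shown leave open what concentration produces cytotoxicity in any member of the series, and whether any substitution alters it.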